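This account rests on a few compounds, and the source may have more. Where it says the series, first, only, none or still open, it means among the compounds named here.

In a functional assay on KM12 cells (Homo sapiens) for inhibition, read by sulforhodamine B assay, with a stated time of 96 h (a higher number here means a weaker inhibitor of growth, a lower number a stronger inhibitor of growth), compound 1 `CC[C@@H](Nc1nc(NCc2ccccn2)c2ncn(C(C)C)c2n1)C(C)(C)O` gives > 50000 nM, which is a limit of the assay and not a number. For the measured compounds named here, compound 2 `CC[C@@H](Nc1nc(NCc2ccccn2)c2ncn(C(C)C)c2n1)C(C)O` gives 37000 nM, the only true number so far. Compound 3 `CCC(O)[C@@H](CC)Nc1nc(NCc2ccccn2)c2ncn(C(C)C)c2n1` has methyl in place of hydrogen on a saturated chain carbon, two bonds along the chain from an oxygen on a saturated carbon, so 1-hydroxyethyl becomes 1-hydroxypropyl (methyl in place of hydrogen on a saturated chain carbon, two bonds along the chain from an oxygen on a saturated carbon). Going by the values given here, one measured step bears on this change, as it also exchanges methyl and hydrogen, although on a saturated chain carbon bound to an oxygen: an at least 1.3-fold lower number from compound 1 to compound 2 (0.13 log units; that floor lies within the scatter). That step shows no change beyond the scatter, so no step beyond the scatter is expected in this assay here. The expected step is small: no change at the digits printed from compound 2 to compound 3 (within the scatter). For compound 3 the estimated value is 37000 nM, with an expected range of 17000 nM to 50000 nM.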

Compound 3, concentration for 50% growth inhibition: 45000 nM
The estimate for compound 3 lay 1.2-fold (0.09 log units) below the measured number; measured number inside the range.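

Unlike the step from compound 1 to compound 2, which gave only a floor, this is the first step in this assay between two true numbers: a 1.2-fold higher number from compound 2 to compound 3 (0.09 log units; within the scatter). Going from 1-hydroxyethyl to 1-hydroxypropyl, the added methyl at this place therefore leaves the growth inhibition unchanged as far as this assay can tell. Compound 1 gives > 50000 nM, which is a limit and not a number, so its step again yields only a floor, an at least 1.1-fold lower number from compound 1 to compound 3 (0.04 log units; that floor lies within the scatter), and how the three compounds truly compare stays unresolved: the limit of > 50000 nM in this assay, at which 1 of the 3 values shown sits.

From the compounds shown here alone, whether a longer chain than 1-hydroxypropyl would shift the number beyond the scatter remains open. So does the effect of an amine or a carboxylic acid in place of the hydroxyl group.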